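Hydroxy for methoxy on the aryl-thiadiazole amine series

The source may report more compounds than this note shows. Statements on the series, on what has been measured and on what is new or still open speak of the compounds shown alone.

Within the data shown here, compound 1 `COc1ccc(-c2nnc(Nc3csc(-c4ccccc4)c3)s2)cc1` is the only member of this set with a number: in a functional assay on U-373MG ATCC cells (Homo sapiens) for inhibition, read by colorimetric assay and MTT assay, with a stated time of 72 h (a higher number here means a weaker inhibitor, a lower number a stronger inhibitor), compound 1 gives 92000 nM, a weak result. Compound 2 `COc1ccc(-c2nnc(Nc3csc(-c4ccc(C)cc4)c3)s2)cc1` carries a methyl on the phenyl attached to the thiophene, and in this assay compound 2 gives "not determined" (no result reported), so nothing can be said about where it stands relative to compound 1. Compound 3 `Cc1ccc(-c2cc(Nc3nnc(-c4ccc(O)cc4)s3)cs2)cc1` is the next analogue, to be measured in this assay. It differs from compound 2 by hydrogen in place of methyl on an oxygen on an aromatic ring; in words, hydrogen in place of methyl on an oxygen on an aromatic ring, read one bond further out as methoxy to hydroxy, or 4-methoxyphenyl to 4-hydroxyphenyl. Among the measured compounds shown here, no step between two measured compounds exists to anchor this change, so the direction of any shift in this assay is open, and a move no larger than the usual scatter is the default expectation. For the measured compounds named here, the only measured anchor is compound 1, which in this assay gives 92000 nM, and the set as a whole looks weak. Compound 3 is therefore expected to give about 80000 nM, with an estimated range of 20000 nM to 300000 nM, and there is a fair chance the assay reports only a limit.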

Compound 3, half-maximal inhibitory concentration: 8000 nM
Beside the measured number, compound 3's estimate is 10-fold (1.00 log units) above it; measured number below the stated range.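

In this assay, among these compounds, compound 2 has no single number, so no step from it to compound 3 can be read. The compounds shown leave open what methoxy to hydroxy does on its own, with everything else held the same. No supporting data bear on the result for compound 3.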